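Thiosemicarbazone series: chloro in place of cyano

The source may report more compounds than this note shows. Statements on the series, on what has been measured and on what is new or still open speak of the compounds shown alone.

Three compounds of the series have numbers in a functional assay on HeLa cells (Homo sapiens) for antiproliferative activity, read by sulforhodamine B assay, with a stated time of 72 h (a higher number here means a weaker inhibitor, a lower number a stronger inhibitor), so far. Compound 1 `N#Cc1ccc(NC(=S)N/N=C/c2ccc3ccccc3n2)cc1` gives 20000 nM in this assay, the higher of the two numbers obtained. Compound 2 `CN(C)C(=S)N/N=C/c1cnc2ccccc2n1` gives 750 nM in this assay, a gap from compound 1 that lies beyond the scatter of repeated measurements. Compound 3 `Cc1ccc(NC(=O)N/N=C/c2ccc3ccccc3n2)cc1` reaches only the limit of the assay, > 100000 nM, and no number is known for it; the relevant fact is the limit of > 100000 nM in this assay, at which 1 of the 3 values shown sits.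

The next compound, compound 4 `S=C(N/N=C/c1ccc2ccccc2n1)Nc1ccc(Cl)cc1`, differs from compound 1 in one place: chloro in place of cyano on an aromatic carbon. The change keeps the thiosemicarbazide linker and the aryl group of compound 1 and alters only the substituent that sits para to a large group.

Within the data shown here, no step between measured compounds isolates this kind of change, so the expectation rests on the value of compound 1 alone. A step of modest size, within or close to the scatter, is expected from compound 1 to compound 4 in this assay, a 1.7-fold lower number from compound 1 to compound 4 (0.22 log units; within the scatter), with a slight lean toward a lower number. Compound 4 is therefore estimated at 12000 nM, expected between 3000 nM and 45000 nM.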

Compound 4, half-maximal inhibitory concentration: > 100000 nM
Compound 4: no number, only a limit; the forecaster's own chance of this, stated with the estimate: 10%; middle value at least 8.3-fold (0.92 log units) from the limit.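

In this assay, among these compounds, the change from 4-cyanophenyl to 4-chlorophenyl is the first single-place comparison, and it gives an at least 5.0-fold higher number from compound 1 to compound 4 (0.69 log units; beyond the scatter). This shows that the aromatic carbon para to a large group is not indifferent to its substituent, since the exchange of cyano for chloro alone, with the thiosemicarbazide linker and the rest of compound 1 kept, moves the result beyond the scatter. In this assay compound 4 gives > 100000 nM, which is a limit of the assay and not a number, so the step is bounded on one side only, and the series now reaches this limit more than once: the limit of > 100000 nM in this assay, at which 2 of the 4 values shown sit.

The compounds shown do not tell whether the nitrile is specifically favoured at this place or chloro specifically disfavoured, since only these two substituents are compared there. A methoxy group, an amine or a carboxylic acid at the same place would test whether any substituent can match or improve on compound 1, which gives 20000 nM.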